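The source may report more compounds than this note shows. Statements on the series, on what has been measured and on what is new or still open speak of the compounds shown alone.

Compound 1 `O=c1cc(NCc2ccccc2)sc2c([N+](=O)[O-])cc(C(F)(F)F)cc12`: > 64 ug/mL
Compound 2 `CC1COC2(CCN(c3cc(=O)c4cc(C(F)(F)F)cc([N+](=O)[O-])c4s3)CC2)O1`: > 64 ug/mL

In an ADME assay on Vero cells (Chlorocebus sabaeus) for cytotoxicity, read by MTT assay, with a stated time of 48 h (on this read-out lower numbers stand for stronger inhibition and higher numbers for weaker inhibition), compound 1 gives > 64 ug/mL, which is a limit of the assay rather than a number. Compound 2 likewise gives > 64 ug/mL, again a limit. Compound 1 therefore stands at the limit of > 64 ug/mL in this assay, at which 2 of the 2 values shown sit, so neither value orders it against any other.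

Compound 3 `COc1ccc(CNc2cc(=O)c3cc(C(F)(F)F)cc([N+](=O)[O-])c3s2)cc1OC` has not yet been measured in this assay. It differs from compound 1 in one place: 3,4-dimethoxyphenyl in place of phenyl on a saturated chain carbon bound to a nitrogen on an aromatic ring. Among the compounds with values here, no step between measured compounds is available, so from the two limits alone the expected step from compound 1 to compound 3 is a step that the limit leaves unreadable from compound 1 to compound 3, with no change expected beyond the usual scatter. The expected value for compound 3 in this assay is 80 ug/mL, estimated to lie between 40 ug/mL and 160 ug/mL, with a good chance that only a limit is again reported.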

Compound 3, half-maximal inhibitory concentration: > 64 ug/mL
Compound 3 ended at the assay's limit; the forecaster's own chance of this, stated with the estimate: 75%; the middle value is on the limit's open side.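

Within the data shown here, no step from compound 1 to compound 3 can be read, because both values are limits and not numbers: the limit of > 64 ug/mL in this assay, at which 3 of the 3 values shown sit. The compounds shown leave open at what concentration any of them would inhibit these cells, and whether 3,4-dimethoxyphenyl in place of phenyl changes that concentration.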